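The source may report more compounds than this note shows. Statements on the series, on what has been measured and on what is new or still open speak of the compounds shown alone.

Measured in an in vitro ADME assay on microsomes from liver (Mus musculus) for pharmacokinetics, read by LC-MS, with a stated time of 10 min, tested at 1 uM; on this read-out higher numbers stand for fast clearance and lower numbers for slow clearance:
- Compound 1 `CN1C[C@H](C(=O)Nc2ccc(Br)cc2)[C@@H](c2ccc(/C=C/C(=O)Nc3ccccc3N)cc2)C1`: 16 mL/min/kg
- Compound 2 `CN1C[C@H](C(=O)Nc2cccc(Cl)c2)[C@@H](c2ccc(/C=C/C(=O)Nc3ccccc3N)cc2)C1`: 58 mL/min/kg
- Compound 3 `COc1cccc(NC(=O)[C@H]2CN(C)C[C@@H]2c2ccc(/C=C/C(=O)Nc3ccccc3N)cc2)c1`: 65 mL/min/kg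

Compound 3, with the 3-methoxyphenyl on an amide-type nitrogen, gives 65 mL/min/kg. Its number cannot be told apart from that of compound 2, at a 1.1-fold higher number from compound 2 to compound 3 (0.05 log units; within the scatter), a step within the scatter. Both lie clearly above compound 1, at a 4.1-fold higher number from compound 1 to compound 3 (0.61 log units; beyond the scatter) and a 3.6-fold higher number from compound 1 to compound 2 (0.56 log units; beyond the scatter), and both of these steps are beyond the scatter.

Compound 4 `CN1C[C@H](C(=O)Nc2ccc(F)c(Cl)c2)[C@@H](c2ccc(/C=C/C(=O)Nc3ccccc3N)cc2)C1` has 3-chloro-4-fluorophenyl in place of 3-methoxyphenyl on an amide-type nitrogen. Among the compounds with values here, no measured compound carries this group. It reads partly as the 3-chlorophenyl of compound 2, which gives 58 mL/min/kg, and partly, with fluoro for bromo, as the 4-bromophenyl of compound 1, which gives 16 mL/min/kg. How far fluoro would follow bromo is not shown by any measurement, so a position between these two values seems the fair expectation. A lower number is expected, but only a step no larger than the scatter, estimated as a 1.9-fold lower number from compound 3 to compound 4 (0.27 log units; within the scatter). The estimated clearance of compound 4 is 35 mL/min/kg, with an expected range from 15 mL/min/kg to 75 mL/min/kg.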

Compound 4, clearance: 34 mL/min/kg
The estimate for compound 4 lay 1.0-fold (0.01 log units) above the measured number; the range from low to high includes it.
By their numbers in this assay, from the lowest: compound 1; then compounds 4, 2 and 3 (each within the scatter of the next).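

In this assay, within the data shown here, 3-chloro-4-fluorophenyl on the amide-type nitrogen stays within the scatter of both earlier groups at the high end of the series, whether it is read against 3-methoxyphenyl (a 1.9-fold lower number from compound 3 to compound 4 (0.28 log units; within the scatter)) or against 3-chlorophenyl, where the only change is fluoro in place of hydrogen on an aromatic carbon (a 1.7-fold lower number from compound 2 to compound 4 (0.23 log units; within the scatter)). Against 4-bromophenyl, the same group gives a modest step beyond the scatter (a 2.1-fold higher number from compound 1 to compound 4 (0.33 log units; beyond the scatter)), so among these four compounds only compound 1 stands apart from the other three. Fluoro added to the 3-chlorophenyl ring therefore does not carry the number of compound 2 clearly towards that of compound 1, and nothing available explains these numbers.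

The compounds shown leave open whether the low number of compound 1 goes with the bromo itself or with a single halogen on the ring, a question that 4-chlorophenyl or 4-fluorophenyl on the same nitrogen would address. They also leave open how this position responds to groups unlike these aryl rings, such as a pyridyl ring or a phenyl ring carrying a carboxylic acid or an amine.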